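Bromofuranone side chain: hydroxy removed from compound 2

The source may report more compounds than this note shows. Statements on the series, on what has been measured and on what is new or still open speak of the compounds shown alone.

Compound 1 `CCC[C@@H](OC(C)=O)C1=C(Br)C(=C(Br)Br)OC1=O`: 1.1 ug/mL
Compound 2 `CCC[C@@H](O)C1=C(Br)C(=C(Br)Br)OC1=O`: 1.7 ug/mL

Both numbers come from a functional assay on Lu1 cells (Homo sapiens) for cytotoxicity; a lower number here means that less compound is needed, a higher number that more compound is needed for the effect. Compound 2 holds the higher of the two, but its nearest neighbour, compound 1, sits within the scatter of it. Among the compounds with values here, compound 3 `CCCCC1=C(Br)C(=C(Br)Br)OC1=O` is still unmeasured. hydrogen in place of hydroxy on a saturated chain carbon bound to a double-bonded ring carbon and a saturated chain carbon The only measured step touching this part of the molecule is a 1.5-fold higher number from compound 1 to compound 2 (0.19 log units; within the scatter), which swapped acetyl for hydrogen on an oxygen on a saturated carbon and stayed within the scatter. No step beyond the scatter is therefore expected here. Compound 3 is estimated at 2 ug/mL, between 1 ug/mL and 4 ug/mL. The expected step is a 1.2-fold higher number from compound 2 to compound 3 (0.07 log units; within the scatter).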

Compound 3, concentration for half-maximal effect: > 10.3 ug/mL
Compound 3: a limit, no number; the forecaster's own chance of this, stated with the estimate: 5%; middle value at least 5.1-fold (0.71 log units) from the limit.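

In this assay, hydrogen in place of hydroxy gives an at least 6.0-fold higher number from compound 2 to compound 3 (0.78 log units; beyond the scatter), and hydrogen in place of acetoxy gives an at least 9.3-fold higher number from compound 1 to compound 3 (0.97 log units; beyond the scatter), whereas the earlier change on that oxygen gave only a 1.5-fold higher number from compound 1 to compound 2 (0.19 log units; within the scatter). The oxygen-bearing side chains of compound 1 and compound 2 thus read alike in this assay, while the plain butyl chain of compound 3 separates clearly from both. Compound 3 carries a limit, not a number: the limit of > 10.3 ug/mL in this assay, at which 1 of the 3 values shown sits.

Going by these compounds, the full size of both steps remains open. Also open, on these data alone, is whether an amine or a methoxy group on this carbon would read like hydroxy or like hydrogen.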